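Hydroxyphenyl pyridines: shifting the hydroxyl before measurement

A few compounds are considered here, and "the series" means these few. Any claim that something is new, unique, unknown or untested is made for them only; others in the source may bear on it.

Measured so far:
Compound 1 `Oc1cccc(-c2cc(-c3cccnc3)nc(-c3cccc(Cl)c3)c2)c1` – in a functional assay on HCT-15 cells (Homo sapiens) for cytotoxicity, read by CCK-8 assay and cell counting, with a stated time of 2 days (on this read-out higher numbers stand for weaker inhibition and lower numbers for stronger inhibition), compound 1 gives "not determined" (no result reported).
Compound 2 `Oc1cccc(-c2cc(-c3cccc(Cl)c3)nc(-c3ccco3)c2)c1` – in this assay compound 2 gives 2460 nM.
Compound 3 `Oc1cccc(-c2cc(-c3ccsc3)nc(-c3cccc(Cl)c3)c2)c1` – in this assay compound 3 gives 2510 nM.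

Compound 2 and compound 3 sit together: the step of a 1.0-fold higher number from compound 2 to compound 3 (0.01 log units; within the scatter) is within the scatter, so neither can be set apart from the other. Compound 4 `Oc1ccc(-c2cc(-c3cccc(Cl)c3)nc(-c3ccco3)c2)cc1` differs from compound 2 by 4-hydroxyphenyl in place of 3-hydroxyphenyl on an aromatic carbon. Going by the values given here, no measured step touches the hydroxyphenyl group; the one measured step alters a different ring, so it does not bear on this change. With nothing pointing either way, no step beyond the scatter is expected. Compound 4 is therefore estimated at 2500 nM (range 900 nM to 7000 nM), a step of a 1.0-fold higher number from compound 2 to compound 4 (0.01 log units; within the scatter) expected from compound 2.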

Compound 4, half-maximal inhibitory concentration: 8020 nM
Estimate against measurement, compound 4: 3.2-fold (0.51 log units) below, outside the stated range (above it).
By their numbers in this assay, from the lowest: compounds 2 and 3 (each within the scatter of the next); then compound 4.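

In this assay, going by these compounds alone, 4-hydroxyphenyl in place of 3-hydroxyphenyl gives a 3.3-fold higher number from compound 2 to compound 4 (0.51 log units; beyond the scatter), the first step beyond the scatter and the first at this position. The two groups have the same atoms, so the placement of the hydroxyl on this ring alone registers in the read-out, whereas the earlier ring change gave only a 1.0-fold higher number from compound 2 to compound 3 (0.01 log units; within the scatter). No measurement at hand explains the step.

Still open, on these data alone, is whether the same shift counts with thiophen-3-yl in place of furan-2-yl. Also open, as far as these compounds go, is how an amine or a methoxy group would read in place of the hydroxyl.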